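This account rests on a few compounds, and the source may have more. Where it says the series, first, only, none or still open, it means among the compounds named here.

Measured compounds:
- compound 2 `CC(=O)N1CCC(C[C@@H](c2nc3ccccc3n2C)N2C(=O)CN(c3ccc(Oc4ccccc4)cc3)C2=O)CC1`: 0.002 nM
- compound 1 `Cc1ccc2nc([C@H](CC3CCN(C(=O)C4CCCC4)CC3)N3C(=O)CN(c4ccc(Oc5ccccc5)cc4)C3=O)n(C)c2c1`: 0.006 nM

In an assay on cells for antagonist activity at Bile acid receptor (Homo sapiens), read by a luciferase reporter, with a stated time of 24 h (a higher number here means a weaker inhibitor, a lower number a stronger inhibitor), compound 2 gives 0.002 nM, the lowest of the two numbers shown. Its nearest neighbour is compound 1, which in this assay gives 0.006 nM, a higher number, and the gap between them lies beyond the scatter of repeated measurements. Compound 3 `CC(=O)N1CCC(C[C@@H](c2nc3ccc(Cl)cc3n2C)N2C(=O)CN(c3ccc(Oc4ccccc4)cc3)C2=O)CC1` is not yet measured. It differs from compound 2 in one place: chloro in place of hydrogen on an aromatic carbon of the shared core. For the measured compounds named here, no measured pair shows this exact change, so there is no step to lean on. A single chloro added to an aromatic carbon is a modest change, and the expectation is a step of a 1.5-fold higher number from compound 2 to compound 3 (0.18 log units; within the scatter), which stays within the usual scatter. Compound 3 is therefore estimated at 0.003 nM, with a range from 0.001 nM to 0.01 nM.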

Compound 3, half-maximal inhibitory concentration: 0.8 nM
For compound 3 the middle estimate is 270-fold (2.43 log units) below the measured one, and the stated range ends below it.
By their numbers in this assay, from the lowest: compound 2; then compound 1; then compound 3.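

In this assay, turning the 1-methyl-1H-benzimidazol-2-yl group into the 6-chloro-1-methyl-1H-benzimidazol-2-yl group brings a 400-fold higher number from compound 2 to compound 3 (2.60 log units; beyond the scatter), a large step well beyond the scatter. This aromatic carbon is therefore far from indifferent: a single added heavy atom here is enough to weaken the inhibitor greatly, something the earlier values alone could not reveal. Nothing measured here explains why one chlorine atom has so large an effect.

As far as these compounds go, it remains open whether this loss is specific to chloro or would also come with a fluoro or a methoxy on the same carbon. Also open, from the compounds shown here alone, is whether chloro on the other carbons of this ring would cost as much, and whether the same change would have a similar effect in compound 1.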